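The source may hold more compounds than are shown below. What is called first, only, known or untested is meant among the compounds shown, and "the series" means these compounds.

Within the data shown here, in a functional assay on HCT-116 cells (Homo sapiens) for inhibition (on this read-out higher numbers stand for weaker inhibition and lower numbers for stronger inhibition), compound 1 `CCNC(=O)c1noc(-c2cc(C(C)C)c(O)cc2O)c1-c1cc(CN2CCCC2)no1` gives 51 nM, the only number available in this small set. Compound 2 `CCNC(=O)c1noc(-c2cc(C(C)C)c(O)cc2O)c1-c1cc(C(=O)O)no1`, the carboxy analogue, has no value to stand on: its entry reads "not determined" (no result reported). Compound 3 `CCNC(=O)c1noc(-c2cc(C(C)C)c(O)cc2O)c1-c1cc(C(=O)NC)no1` has not been measured yet. It differs from compound 2 by methylamino in place of hydroxy on a carbonyl carbon, with carboxy changed to methylcarbamoyl. With no starting number, the step cannot be sized from the data, though a moderate step towards stronger inhibition in this assay is expected. Among the measured compounds shown here, the only anchor is compound 1 at 51 nM. For compound 3 the estimated value is 60 nM, with an expected range of 20 nM to 200 nM.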

Compound 3, half-maximal inhibitory concentration: 124 nM
Compound 3: middle estimate off by 2.1-fold (0.32 log units), on the low side; measured number inside the range.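

In this assay, methylcarbamoyl in place of (pyrrolidin-1-yl)methyl on an aromatic carbon gives a 2.4-fold higher number from compound 1 to compound 3 (0.39 log units; beyond the scatter), so inhibition at this position persists without the pyrrolidine ring but is modestly weaker. Compound 2 has no number, so the step to compound 3 from the carboxy analogue cannot be read. Nothing available here explains the shift.

The compounds shown leave open how an ethylcarbamoyl or dimethylcarbamoyl group would compare with methylcarbamoyl. They also leave open whether a (piperidin-1-yl)methyl or morpholinomethyl group would match the (pyrrolidin-1-yl)methyl of compound 1.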